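Replacing dichlorophenyl with dimethoxyphenyl on the carbonyl carbon

This account rests on a few compounds, and the source may have more. Where it says the series, first, only, none or still open, it means among the compounds named here.

Compounds with numbers so far:
compound 1 `COc1cc(-c2cc(/C=C/C(=O)c3ccc(N)cc3)[nH]n2)cc(OC)c1OC` gives 36%
compound 2 `COc1cc(-c2cc(/C=C/C(=O)c3ccc(Cl)c(Cl)c3)[nH]n2)cc(OC)c1OC` gives 71%

Compound 1 and compound 2 share one core and differ only in the ring on the carbonyl carbon. Within the data shown here, in a functional assay on CCRF-CEM cells (Homo sapiens) for cytotoxicity, read by sulforhodamine B assay, with a stated time of 48 h, tested at 1 uM (a lower number here means a stronger effect, a higher number a weaker effect of the compound at the concentration tested), compound 1 gives 36%, while compound 2 gives 71%, the highest of the two numbers; its only neighbour is compound 1, and the step of a number 35 percentage points higher from compound 1 to compound 2 (beyond the scatter) lies beyond the scatter. Compound 3 `COc1ccc(C(=O)/C=C/c2cc(-c3cc(OC)c(OC)c(OC)c3)n[nH]2)cc1OC` is not yet measured in this assay. It differs from compound 2 in one place: 3,4-dimethoxyphenyl in place of 3,4-dichlorophenyl on a carbonyl carbon. Among the measured compounds shown here, the only measured step that bears on this change is a number 35 percentage points higher from compound 1 to compound 2 (beyond the scatter), which shows that the ring on the carbonyl carbon can move the read-out by a large amount. Nothing measured here shows the 3,4-dimethoxyphenyl group itself, so the direction is uncertain, but a ring with two hydrogen-bond acceptors is expected to sit nearer compound 1 than compound 2 does. For compound 3 a step of a number 21 percentage points lower from compound 2 to compound 3 (beyond the scatter) is therefore expected. Compound 3 is estimated at 50%, within a range from 25% to 80%.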

Compound 3, a percentage reported as activity, at one concentration (the size of the read-out at that concentration, not a potency): 39%
Beside the measured number, compound 3's estimate is 11 percentage points above it, within the range that was stated.
By their numbers in this assay, from the lowest: compounds 1 and 3 (each within the scatter of the next); then compound 2.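

In this assay, moving from 3,4-dichlorophenyl to 3,4-dimethoxyphenyl on the carbonyl carbon gives a number 32 percentage points lower from compound 2 to compound 3 (beyond the scatter) and so shows that 4-aminophenyl is not the only ring that separates from 3,4-dichlorophenyl at this position. The comparison of the two rings that share the low end gives a number 3 percentage points higher from compound 1 to compound 3 (within the scatter), so 3,4-dimethoxyphenyl and 4-aminophenyl cannot be told apart here even though they carry different substituents, and the low read-out is therefore not tied to one particular group. Among the three rings, 3,4-dichlorophenyl alone stands apart, with compound 2 showing the weakest effect at the concentration tested, while nothing shown gives a reason for these steps.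

The compounds shown leave open whether a plain phenyl, a phenyl with a single methoxy or a phenyl with a single chlorine on the carbonyl carbon would group with compound 1 and compound 3 or with compound 2. They also leave open whether these rings would show a stronger or weaker effect at any other concentration, as the read-out comes from one concentration only.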